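This account rests on a few compounds, and the source may have more. Where it says the series, first, only, none or still open, it means among the compounds named here.

Compound 1 `Nc1cc(N)c2nc(-c3ccccc3)c(NCc3ccc(Cl)c(Cl)c3)nc2c1` gives 15800 nM in a functional assay on M14 cells (Homo sapiens) for inhibition, read by sulforhodamine B assay, with a stated time of 48 h; a lower number here means a stronger inhibitor of growth, a higher number a weaker inhibitor of growth.
Compound 2 `COc1ccc(CNc2nc3cc(N)cc(N)c3nc2-c2ccccc2)cc1OC` gives 4270 nM in this assay.
Compound 3 `Nc1cc(N)c2nc(-c3ccccc3)c(NCc3ccc(F)cc3)nc2c1` gives 23400 nM in this assay.

Compound 3 carries the highest of the three numbers in this assay. Its gap to compound 1 is within the scatter, so the two cannot be ordered, whereas the step of a 5.5-fold higher number from compound 2 to compound 3 (0.74 log units; beyond the scatter) lies beyond it. Compound 4 `COc1ccc(CNc2nc3cc(N)cc(N)c3nc2-c2ccccc2)cc1` is not yet measured. The change from compound 3 reads (methoxy in place of fluoro on an aromatic carbon). The step that bears on it most directly is a 5.5-fold higher number from compound 2 to compound 3 (0.74 log units; beyond the scatter), though that step swaps in two methoxy groups rather than one. The step of a 1.5-fold higher number from compound 1 to compound 3 (0.17 log units; within the scatter) shows that the dichloro and fluoro substituents give numbers that cannot be told apart, while a 3.7-fold lower number from compound 1 to compound 2 (0.57 log units; beyond the scatter) again favours the methoxy pattern. A single methoxy group is therefore expected to lower the number, by less than the full two-methoxy step. Compound 4 is estimated at 8000 nM, within 3500 nM to 20000 nM, corresponding to an expected step of a 2.9-fold lower number from compound 3 to compound 4 (0.47 log units; beyond the scatter) in this assay.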

Compound 4, concentration for 50% growth inhibition: 18200 nM
Estimate against measurement, compound 4: 2.3-fold (0.36 log units) below; measured number inside the range.
By their numbers in this assay, from the lowest: compound 2; then compounds 1, 4 and 3 (each within the scatter of the next).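

In this assay, the change at this aromatic carbon gives a 1.3-fold lower number from compound 3 to compound 4 (0.11 log units; within the scatter), so a single methoxy group in this place cannot be told apart from fluoro, and a 1.2-fold higher number from compound 1 to compound 4 (0.06 log units; within the scatter) places the 4-methoxyphenyl compound level with the 3,4-dichlorophenyl one as well. The lower number of compound 2 therefore does not come with the methoxy group on this carbon alone: a 4.3-fold higher number from compound 2 to compound 4 (0.63 log units; beyond the scatter) shows that the step appears only when the second methoxy group is also present. No measurement shown gives a reason for this difference.

The compounds shown leave open whether the second methoxy group would lower the number without the one on this carbon. They also leave open how an amine, a hydroxyl or a longer chain such as ethoxy would read on this carbon.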